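Benzyl fluorine pattern swap on the shared core

The source may hold more compounds than are shown below. What is called first, only, known or untested is meant among the compounds shown, and "the series" means these compounds.

Measured so far:
compound 2, `CN(C)c1ccc(C(=O)Nc2n[nH]c3c2CN(Cc2cccc(F)c2F)C3(C)C)cc1`: 69 nM
compound 1, `CC1(C)c2[nH]nc(NC(=O)c3ccc4ncccc4c3)c2CN1Cc1cc(F)cc(F)c1`: 180 nM

In an assay on Sf21 cells for inhibition of high affinity nerve growth factor receptor (Homo sapiens), read by HTRF, with a stated time of 30 min, in the presence of a further agent that is not named here (a lower number here means a stronger inhibitor, a higher number a weaker inhibitor), compound 2 gives 69 nM, the lowest of the two numbers shown. Compound 1 gives 180 nM, a gap beyond the scatter, but compound 1 and compound 2 differ in two places, so no single step can be read from them. Compound 3 `CN(C)c1ccc(C(=O)Nc2n[nH]c3c2CN(Cc2cc(F)cc(F)c2)C3(C)C)cc1` is not yet measured. It differs from compound 2 by 3,5-difluorophenyl in place of 2,3-difluorophenyl on a saturated chain carbon bound to an amine nitrogen in a ring. Among the compounds with values here, no measured pair isolates this change, so the expected step from compound 2 to compound 3 is small, toward a higher number or none beyond the scatter, written as a 1.6-fold higher number from compound 2 to compound 3 (0.20 log units; within the scatter). Compound 3 is estimated at 110 nM, in a range from 40 nM to 300 nM.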

Compound 3, half-maximal inhibitory concentration: 96 nM
Estimate against measurement, compound 3: 1.1-fold (0.06 log units) above; the range from low to high includes it.
By their numbers in this assay, from the lowest: compounds 2, 3 and 1 (each within the scatter of the next, the first and the last beyond it).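

In this assay the swap of 2,3-difluorobenzyl to 3,5-difluorobenzyl reads as a 1.4-fold higher number from compound 2 to compound 3 (0.14 log units; within the scatter) and so does not separate the two fluorine patterns at this place. With 3,5-difluorobenzyl held constant, 4-(dimethylamino)phenyl in place of quinolin-6-yl on a carbonyl carbon reads as a 1.9-fold lower number from compound 1 to compound 3 (0.27 log units; within the scatter) and does not separate those two groups either. No accompanying measurement offers an explanation for either step. Still open, on these data alone, is how this place responds to a benzyl without fluorine, a pyridylmethyl or a longer chain.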